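The compounds below may be only part of what the source reports. "The series", "measured", "known", "first", "only" and "open" are said of these compounds alone.

Measured in a functional assay on MDA-MB-231 cells (Homo sapiens) for inhibition, read by MTT assay, with a stated time of 48 h; on this read-out lower numbers stand for stronger inhibition of growth and higher numbers for weaker inhibition of growth:
- Compound 1 `NS(=O)(=O)c1ccc(NC(=S)Nc2ccc3ncnc(Nc4cccc(Br)c4)c3c2)cc1`: > 30000 nM (a limit)
- Compound 2 `Fc1ccc(NC(=S)Nc2ccc3ncnc(Nc4cccc(Br)c4)c3c2)cc1Cl`: 300 nM
- Compound 3 `S=C(Nc1ccc(Br)cc1)Nc1ccc2ncnc(Nc3cccc(Br)c3)c2c1`: > 30000 nM (a limit)

Compound 3 gives only a limit, > 30000 nM. That places it at the limit of > 30000 nM in this assay, at which 2 of the 3 values shown sit, and compound 1 sits there too. The comparison between them yields a step that the two limits leave unreadable from compound 1 to compound 3.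

Compound 4 `S=C(Nc1ccc(Cl)c(Cl)c1)Nc1ccc2ncnc(Nc3cccc(Br)c3)c2c1` has 3,4-dichlorophenyl in place of 4-bromophenyl on an amide-type nitrogen.

For the measured compounds named here, two measured steps bear on this change. The closer one is an at least 100-fold higher number from compound 2 to compound 3 (2.00 log units; beyond the scatter), which exchanges 3-chloro-4-fluorophenyl for the same 4-bromophenyl that compound 4 gives up. The other, an at least 100-fold lower number from compound 1 to compound 2 (2.00 log units; beyond the scatter), also shows how much the group on this nitrogen can matter. Going by the values given here, the group entering compound 4 resembles that of compound 2, so a large move to a lower number is expected in this assay, though perhaps not the full distance, and with only three compounds a return to the limit remains possible.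

The expected step is an at least 25-fold lower number from compound 3 to compound 4 (1.39 log units; beyond the scatter).

Compound 4 is estimated at 1200 nM.

The expected range for compound 4 runs from 200 nM to 15000 nM.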

Compound 4, concentration for 50% growth inhibition: 4800 nM
Beside the measured number, compound 4's estimate is 4.0-fold (0.60 log units) below it; the range from low to high includes it.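

In this assay, 3,4-dichlorophenyl on the amide-type nitrogen gives a readable value where 4-bromophenyl and 4-sulfamoylphenyl do not, with an at least 6.2-fold lower number from compound 3 to compound 4 (0.79 log units; beyond the scatter) and an at least 6.2-fold lower number from compound 1 to compound 4 (0.79 log units; beyond the scatter). Measurable inhibition at this position is therefore not confined to 3-chloro-4-fluorophenyl, yet a single exchange on that ring still matters: chloro in place of fluoro gives a 16-fold higher number from compound 2 to compound 4 (1.20 log units; beyond the scatter). Compound 1 and compound 3 both remain at a limit of the assay, so no order can be read between them: the limit of > 30000 nM in this assay, at which 2 of the 4 values shown sit.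

The compounds shown leave open whether the ring needs two halogens at all, which a phenyl group carrying only one chloro would test. Also open, on these data alone, is how an amine or a carboxylic acid on this ring would fare, and whether a carbonyl could replace the thiocarbonyl.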